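Swapping the Chain End on Two Related Cores

A few compounds are considered here, and "the series" means these few. Any claim that something is new, unique, unknown or untested is made for them only; others in the source may bear on it.

Compound 1 `NCCCOc1ccccc1C(=O)Nc1nc2ccc(Oc3ccccc3)cc2s1` and compound 2 `NC(N)=NCCCOc1ccccc1C(=O)Nc1nc2ccc(Oc3ccccc3)cc2s1` share one core, while compound 3 `NCCCOc1ccc(CNc2nc3ccc(Oc4ccccc4)cc3s2)cc1` and compound 4 `NC(N)=NCCCOc1ccc(CNc2nc3ccc(Oc4ccccc4)cc3s2)cc1` share another; how the two cores differ is not broken down here. In an assay on isolated protein for inhibition of Voltage-dependent N-type calcium channel subunit alpha-1B (Rattus norvegicus) (on this read-out higher numbers stand for an effect only at larger amounts of compound and lower numbers for an effect already at smaller amounts), compound 1 reaches only (the limit of > 100000 nM in this assay, at which 1 of the 3 values shown sits), so its value > 100000 nM is a limit and not a number. In this assay compound 2 gives 33000 nM, and the change a group of 4 heavy atoms (1 carbon, 3 nitrogen; no ring) in place of one nitrogen atom, on a saturated chain carbon, three bonds along the chain from an oxygen on an aromatic ring thus made a step of an at least 3.0-fold lower number from compound 1 to compound 2 (0.48 log units; beyond the scatter). In this assay compound 3 gives 76000 nM. Compound 4 carries the same change, (a group of 4 heavy atoms (1 carbon, 3 nitrogen; no ring) in place of one nitrogen atom, on a saturated chain carbon, three bonds along the chain from an oxygen on an aromatic ring), and is not yet measured. Because the earlier step was an at least 3.0-fold lower number from compound 1 to compound 2 (0.48 log units; beyond the scatter), a step of similar size, a 3.0-fold lower number from compound 3 to compound 4 (0.48 log units; beyond the scatter), is expected. Compound 4 is accordingly estimated at 25000 nM, most likely between 8000 nM and 60000 nM.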

Compound 4, half-maximal effective concentration: 5800 nM
Compound 4: the middle estimate sits 4.3-fold (0.63 log units) above what was measured; the whole stated range lies above it.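

In this assay the change also lowered the number on the second core, with a 13-fold lower number from compound 3 to compound 4 (1.12 log units; beyond the scatter). The direction of the step therefore carried over between these two cores, but this does not show that its size carried over: the same change on two cores in this assay, an at least 3.0-fold lower number (0.48 log units; beyond the scatter) from compound 1 to compound 2 and a 13-fold lower number (1.12 log units; beyond the scatter) from compound 3 to compound 4; the limit leaves it open whether they differ. Compound 1 stands at > 100000 nM, which is a limit of the assay and not a number: the limit of > 100000 nM in this assay, at which 1 of the 4 values shown sits.

The compounds shown leave open whether the same step would appear with a longer chain, or with a carboxylic acid in place of the amino group at the chain end. They also leave open how the change behaves on any core other than these two.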